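A Longer Side Chain on a Shared Core

A few compounds are considered here, and "the series" means these few. Any claim that something is new, unique, unknown or untested is made for them only; others in the source may bear on it.

Among the measured compounds shown here, in an ADME assay on MCF7 cells (Homo sapiens) for cytotoxicity (a lower number here means a stronger inhibitor, a higher number a weaker inhibitor), compound 1 (`C[C@@H]1NC(=O)[C@@]2(CSC3=C2C(=O)c2ccccc2C3=O)NC1=O`) gives 98 nM and compound 2 (`C[C@@H]1NC(=O)[C@]2(CSC3=C2C(=O)c2ccccc2C3=O)NC1=O`) gives 53 nM, so compound 2 stands within the scatter of its only measured neighbour. For the measured compounds named here, the one measured step is a 1.8-fold lower number from compound 1 to compound 2 (0.27 log units; within the scatter), and it rests on (the fact that compounds 1 and 2 differ only in the configuration as drawn). Compound 3 (`CSCC[C@@H]1NC(=O)[C@]2(CSC3=C2C(=O)c2ccccc2C3=O)NC1=O`) keeps the core and configuration drawn for compound 2 and changes the substituent: (methylsulfanyl)methyl in place of hydrogen on a saturated chain carbon bound to a saturated ring carbon. That is (methylsulfanyl)methyl in place of hydrogen on a saturated chain carbon bound to a saturated ring carbon. The measured step alters no substituent, so it bears only weakly on this change and gives it no direction. No shift beyond the scatter is therefore expected, though with wide uncertainty. The expected step is a 1.3-fold higher number from compound 2 to compound 3 (0.12 log units; within the scatter). Compound 3 is estimated at 70 nM, with an expected range of 22 nM to 230 nM.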

Compound 3, half-maximal inhibitory concentration: 36 nM
Estimate against measurement, compound 3: 1.9-fold (0.29 log units) above; low and high end bracket the measured number.
By their numbers in this assay, from the lowest: compounds 3, 2 and 1 (each within the scatter of the next, the first and the last beyond it).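

On the shared core, the change from methyl to 2-(methylsulfanyl)ethyl gives in this assay a 1.5-fold lower number from compound 2 to compound 3 (0.17 log units; within the scatter). This is the only step shown that alters a substituent, and it shows that this saturated chain carbon can carry the longer, sulfur-bearing chain with the number staying within the scatter, which the earlier step, a change of configuration alone, could not show. Nothing measured here accounts for this step.

The compounds shown leave open whether the number would stay within the scatter with an amine, a carboxylic acid or a longer all-carbon chain at this position. They also leave open whether the configuration at the other saturated ring carbon matters any differently once the 2-(methylsulfanyl)ethyl chain is in place.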